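This account rests on a few compounds, and the source may have more. Where it says the series, first, only, none or still open, it means among the compounds named here.

Measured in a functional assay on Jurkat cells (Homo sapiens) for antiproliferative activity, read by MTT assay, with a stated time of 72 h; on this read-out lower numbers stand for stronger inhibition and higher numbers for weaker inhibition:
- compound 1 `CNc1nc(-c2cc(OC)c(OC)c(OC)c2)c(-c2ccc(C(F)(F)F)cc2)s1`: 3010 nM
- compound 2 `CNc1nc(-c2cc(OC)c(OC)c(OC)c2)c(-c2ccc(OC)cc2)s1`: 34.3 nM

Of these two compounds, compound 2 has the lower number, at 34.3 nM, and so shows the stronger inhibition. Compound 3 `COc1ccc(-c2sc(C)nc2-c2cc(OC)c(OC)c(OC)c2)cc1` keeps the 4-methoxyphenyl group of compound 2 but carries methyl in place of methylamino on an aromatic carbon. Among the measured compounds shown here, the only measured step is large, an 88-fold lower number from compound 1 to compound 2 (1.94 log units; beyond the scatter), but it involves methoxy in place of trifluoromethyl on an aromatic carbon, not the group changed here. It therefore shows only that one substitution can move the number widely in this small set. For the measured compounds named here, no measured step tests the methylamino group, so the expectation is loose: a moderate rise in this assay, towards weaker inhibition. The expected size is a 5.8-fold higher number from compound 2 to compound 3 (0.77 log units; beyond the scatter). For compound 3 the estimated value is 200 nM, with an expected range from 30 nM to 2000 nM.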

Compound 3, half-maximal inhibitory concentration: 1760 nM
Estimate against measurement, compound 3: 8.8-fold (0.94 log units) below, within the range that was stated.
By their numbers in this assay, from the lowest: compound 2; then compounds 3 and 1 (each within the scatter of the next).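

In this assay, among the compounds shown here, the change on the aromatic carbon next to the ring nitrogen and next to the ring sulfur gives a 51-fold higher number from compound 2 to compound 3 (1.71 log units; beyond the scatter), the first measured step at this position. It shows that the number depends strongly on the group at this carbon, and not only on the group replaced between compound 1 and compound 2. The swap removes the nitrogen along with the hydrogen-bond donor and acceptor counted for methylamino, but no measurement available here explains the loss.

On these data alone, this single step cannot separate the nitrogen from the rest of the group, so it remains open whether an unsubstituted amine or dimethylamino at this carbon would stay near compound 2. It also leaves open whether the step would be similar with a group other than 4-methoxyphenyl on the core.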